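Compound 3: one side group changed from compound 2

The compounds below may be only part of what the source reports. "The series", "measured", "known", "first", "only" and "open" are said of these compounds alone.

Compound 1 `CCOC(=O)Cn1cc(C(=O)Nc2cccc(-c3cn(CC(=O)OCC)nn3)c2)nn1` gives > 100000 nM as a limit
Compound 2 `CC(=O)OCCn1cc(C(=O)Nc2cccc(-c3cn(Cc4ccccc4)nn3)c2)nn1` gives > 100000 nM as a limit

Both values come from a functional assay on B16 cells (Mus musculus) for cytotoxicity, read by MTT assay, with a stated time of 48 h (a lower number here means a stronger inhibitor, a higher number a weaker inhibitor), and neither is an exact number. Compound 2 stands with compound 1 at the limit of > 100000 nM in this assay, at which 2 of the 2 values shown sit, and so has no exact reading. Compound 3 `CCOC(=O)Cn1cc(-c2cccc(NC(=O)c3cn(CCOC(C)=O)nn3)c2)nn1` differs from it in one place: ethoxycarbonyl in place of phenyl on a saturated chain carbon bound to an aromatic nitrogen with ethoxycarbonyl in place of phenyl on a saturated chain carbon bound to an aromatic nitrogen. Compound 1 also has ethoxycarbonyl on such a carbon and gives > 100000 nM as a limit. In this assay no change beyond the scatter is expected in either direction. The expected size of the step of a number no higher from compound 2 to compound 3 (the limit leaves the size open) stays within the scatter. Compound 3 is estimated at 100000 nM (range 40000 nM to 250000 nM) and is expected to read as a limit again.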

Compound 3, half-maximal inhibitory concentration: 63000 nM
For compound 3 the middle estimate is 1.6-fold (0.20 log units) above the measured one; measured number inside the range.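

Compound 3, at 63000 nM in this assay, gives the first exact number among these compounds. Ethoxycarbonyl in place of phenyl on a saturated chain carbon bound to an aromatic nitrogen gives an at least 1.5-fold lower number from compound 2 to compound 3 (0.20 log units; that floor lies within the scatter), and acetoxymethyl in place of ethoxycarbonyl there gives an at least 1.5-fold lower number from compound 1 to compound 3 (0.20 log units; that floor lies within the scatter). Both steps are only floors, so their true sizes may be larger, because the other compound in each pair sits at a limit: the limit of > 100000 nM in this assay, at which 2 of the 3 values shown sit.

On these data alone, whether either step truly goes beyond the scatter stays open. Also open, as far as these compounds go, is how an amine or a carboxylic acid on this carbon would read.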